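Hydroxy to methoxy on the anilino ring of the core

The source may hold more compounds than are shown below. What is called first, only, known or untested is meant among the compounds shown, and "the series" means these compounds.

Two members of the series have numbers in an assay for inhibition of cytokinin dehydrogenase 2 (Arabidopsis thaliana); on this read-out higher numbers stand for weaker inhibition and lower numbers for stronger inhibition. Compound 1 `COc1cccc(Nc2nc(F)nc3[nH]cnc23)c1` gives 1000 nM in this assay. Compound 2 `Oc1ccc(Nc2nc(Cl)nc3[nH]cnc23)cc1` gives > 100000 nM in this assay, which is a limit of the assay and not a measured number. Compound 2 therefore stands only at the weak end of what this assay can report, with no number of its own; the limit is stated in the limit of > 100000 nM in this assay, at which 1 of the 2 values shown sits, so nothing can be said about how far beyond it compound 2 actually lies. Among the measured compounds shown here, compound 1 and compound 2 differ in more than one place, so their two values show only that one gives a number and the other does not.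

Compound 3 `COc1ccc(Nc2nc(Cl)nc3[nH]cnc23)cc1` has not been measured. It differs from compound 2 by methyl in place of hydrogen on an oxygen on an aromatic ring. For the measured compounds named here, no measured step of this kind exists, so the size of the step is unknown; any step is expected to move toward stronger inhibition or stay within the scatter, since compound 2 sits at the limit and weaker values cannot be reported. Compound 3 is estimated at 20000 nM in this assay, with a range from 2000 nM to 100000 nM. This estimate implies a step of an at least 5.0-fold lower number from compound 2 to compound 3 (0.69 log units; beyond the scatter), which is expected rather than known.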

Compound 3, half-maximal inhibitory concentration: > 100000 nM
Compound 3 ended at the assay's limit; the forecaster's own chance of this, stated with the estimate: 35%; middle value at least 5.0-fold (0.69 log units) away from the limit.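

Compound 2 and compound 3 both sit at a limit of this assay and not at a number, so hydroxy to methoxy gives no readable step between them: the limit of > 100000 nM in this assay, at which 2 of the 3 values shown sit.

Still open, going by these compounds, is whether this change shifts inhibition at all, and which of the several differences from compound 1 separates its number from these two limits.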